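The source may hold more compounds than are shown below. What is called first, only, known or untested is meant among the compounds shown, and "the series" means these compounds.

Compound 1 `CCC(C)(C)Cc1c[nH]c(CCc2ccc(-c3ccccc3O)cc2)n1` gives 133 nM in a functional assay for agonist activity at Bombesin receptor subtype-3 (Homo sapiens); on this read-out higher numbers stand for an effect only at larger amounts of compound and lower numbers for an effect already at smaller amounts; compound 2 `CCC(C)(C)Cc1c[nH]c(CCc2ccc(-c3ccccc3OCc3nc(C(F)(F)F)n[nH]3)cc2)n1` gives 129 nM in this assay, and a 1.0-fold lower number from compound 1 to compound 2 (0.01 log units; within the scatter), so the two numbers lie within the scatter of each other. Compound 3 `CCC(C)(C)Cc1c[nH]c(CCc2ccc(N3CCCC[C@@H]3C(=O)O)cc2)n1` differs from compound 1 in one place: 2-carboxypiperidin-1-yl in place of 2-hydroxyphenyl on an aromatic carbon. No measured step bears directly on this change; the only step shown alters a substituent on the oxygen that compound 3 no longer carries, and it lies within the scatter. For compound 3, a 2.6-fold higher number from compound 1 to compound 3 (0.42 log units; beyond the scatter) is expected, with wide uncertainty. Compound 3 is estimated at 350 nM, within 70 nM to 2000 nM.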

Compound 3, half-maximal effective concentration: 24 nM
The estimate for compound 3 lay 15-fold (1.16 log units) above the measured number, outside the stated range (below it).
By their numbers in this assay, from the lowest: compound 3; then compounds 2 and 1 (each within the scatter of the next).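

Putting 2-carboxypiperidin-1-yl in place of 2-hydroxyphenyl on this aromatic carbon, para to a large group, gives a 5.5-fold lower number from compound 1 to compound 3 (0.74 log units; beyond the scatter) in this assay. This place therefore does not depend on a six-membered aromatic ring of carbon only, and a non-aromatic ring with a hetero atom is accepted there. No available evidence explains the shift.

Open, as far as these compounds go, is whether the carboxylic acid matters, which an unsubstituted piperidine, a methyl ester or a primary amide would test. From the compounds shown here alone, the opposite configuration at the defined stereocentre also remains open.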